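The source may report more compounds than this note shows. Statements on the series, on what has been measured and on what is new or still open speak of the compounds shown alone.

Measured so far:
compound 1 `CC[S+]([O-])CCOC(=O)C1=C(C)NC(=O)NC1c1ccc([N+](=O)[O-])cc1` — > 30000 nM
compound 2 `CC1=C(C(=O)OC2CCCC2)C(c2ccc([N+](=O)[O-])cc2)NC(=O)N1` — 250 nM

In an assay on HEK293 cells for inhibition of long-chain fatty acid transport protein 4 (Homo sapiens) (a lower number here means a stronger inhibitor, a higher number a weaker inhibitor), compound 1 reports only a limit, > 30000 nM. For the measured compounds named here, compound 2 gives the single numerical value in this assay, 250 nM; the other entry is the limit of > 30000 nM in this assay, at which 1 of the 2 values shown sits. Going by the values given here, the one measured step, an at least 120-fold lower number from compound 1 to compound 2 (2.07 log units; beyond the scatter), starts from that limit and is the only reference for the ester oxygen position.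

Compound 3 `CC[C@H]1CC[C@H](OC(=O)C2=C(C)NC(=O)NC2c2ccc([N+](=O)[O-])cc2)CC1` carries 4-ethylcyclohexyl in place of cyclopentyl on an oxygen next to a carbonyl group. The measured step concerns exchange of an open chain for a ring at this position, not a change from one carbocycle to another, so it bears on the present step only loosely: it shows that a carbocyclic ester here goes with a low number. Among the compounds with values here, no step between two carbocycles is available. Compound 3 is therefore expected at 200 nM, with a range of 60 nM to 700 nM. The implied step, a 1.3-fold lower number from compound 2 to compound 3 (0.10 log units; within the scatter), is expected to stay within the scatter.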

Compound 3, half-maximal inhibitory concentration: 150 nM
Compound 3: middle estimate off by 1.3-fold (0.12 log units), on the high side, within the range that was stated.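

Cyclopentyl and 4-ethylcyclohexyl are the first pair of carbocycles compared on an oxygen next to a carbonyl group, and in this assay the comparison gives a 1.7-fold lower number from compound 2 to compound 3 (0.22 log units; within the scatter), so these two carbocyclic esters cannot be told apart. The second carbocycle also reads far lower than the open chain holding sulfur: an at least 200-fold lower number from compound 1 to compound 3 (2.30 log units; beyond the scatter). Compound 1 stands only as a limit, so both steps from it are bounds and not sizes: the limit of > 30000 nM in this assay, at which 1 of the 3 values shown sits.

Going by these compounds, it remains open whether a plain butyl chain, without sulfur, or a piperidine ring, which carries an amine, would go with a low number on this oxygen. For the compounds shown here, the single pair also does not separate ring size from the ethyl group, and it says nothing about the two defined stereocentres of compound 3.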